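Methyl in Place of Fluoro on a Benzyl Ether

This account rests on a few compounds, and the source may have more. Where it says the series, first, only, none or still open, it means among the compounds named here.

Measured compounds:
compound 1, `CCC1(Cc2ccccc2)OS(=O)(=O)C=C1OCc1ccc(F)cc1`, > 50000 nM
compound 2, `CC1(C(c2ccccc2)c2ccccc2)OS(=O)(=O)C=C1OCc1ccccc1`, 200000 nM
compound 3, `CCC1(Cc2ccccc2)OS(=O)(=O)C=C1OCCCCCCc1ccccc1`, < 200000 nM

Of the compounds shown here, three on the shared core have been tested in an ADME assay on HEL cells (Homo sapiens) for cytotoxicity, with a stated time of 3 days; a lower number here means that less compound is tolerated, a higher number that more compound is tolerated. In this assay compound 1 gives > 50000 nM, which is a limit of the assay and not a number. Compound 2 gives a numeric reading of 200000 nM. Compound 3 gives < 200000 nM, again a limit of the assay rather than a number. Compound 1 therefore stands only at a limit, (the limit of > 50000 nM in this assay, at which 1 of the 3 values shown sits), and among the other two values one more is also a limit, (the limit of < 200000 nM in this assay, at which 1 of the 3 values shown sits). For the measured compounds named here, no pair of these three compounds differs in a single place, so no single step between measured compounds can be counted, and nothing here separates the three beyond what each value shows on its own.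

Compound 4 is `CCC1(Cc2ccccc2)OS(=O)(=O)C=C1OCc1ccc(C)cc1`. It differs from compound 1 by methyl in place of fluoro on an aromatic carbon. With a change this small, and with all three measured values sitting at or near the upper reach of this assay, the step from compound 1 to compound 4 is expected to be nothing beyond the scatter, a step that the limit leaves unreadable from compound 1 to compound 4. Compound 4 is estimated at 100000 nM, in a range from 30000 nM to 300000 nM, and the assay may well again report only a limit.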

Compound 4, half-maximal cytotoxic concentration: 41500 nM
The estimate for compound 4 lay 2.4-fold (0.38 log units) above the measured number; low and high end bracket the measured number.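

Compound 4 gives a numeric reading for a 4-methylbenzyl ether on the shared core, where compound 1, its 4-fluorobenzyl counterpart, holds only a limit of the assay. In this assay, methyl in place of fluoro on an aromatic carbon, para to a large group, amounts to an at least 1.2-fold lower number from compound 1 to compound 4 (0.08 log units; that floor lies within the scatter), so this exchange at this position shows no difference that can be told from the scatter, though a larger one is not excluded. The step has only a floor and no measured size because compound 1 stands at a limit and not at a number: the limit of > 50000 nM in this assay, at which 1 of the 4 values shown sits.

The compounds shown leave open how far the reading would move at this position with a methoxy group, a chlorine atom or an amine in place of fluoro or methyl, and whether a benzyl ether with no group on the ring would read like compound 4 at 41500 nM. They also leave open whether a carboxylic acid on the same ring, or a longer chain between the ether oxygen and the ring on this exact core, would shift the reading in this assay by more than the scatter.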